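Swapping a methylphenyl for a dichlorophenyl on a sulfonamide

A few compounds are considered here, and "the series" means these few. Any claim that something is new, unique, unknown or untested is made for them only; others in the source may bear on it.

Of the compounds shown here, two have so far been measured in a functional assay on RH7777 cells for antagonist activity at lysophosphatidic acid receptor 2 (Homo sapiens), read by calcium flux; a higher number here means a weaker inhibitor, a lower number a stronger inhibitor. Compound 1, `Cc1ccccc1N1CCN(C[C@H](C)Nc2nc(C(F)(F)F)nc3ccccc23)CC1`, gives 730 nM in this assay. Compound 2, `Cc1ccc(S(=O)(=O)N2CCN(C[C@H](C)Nc3ncnc4c(C)csc34)CC2)cc1`, gives 170 nM in this assay, which is the lower of the two numbers; compound 1 sits a clear distance above it, beyond the usual scatter of repeated measurements. Within the data shown here, no pair of measured compounds differs in only one place, so no step within the data can be read off directly.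

Compound 3, `Cc1csc2c(N[C@@H](C)CN3CCN(S(=O)(=O)c4ccc(Cl)c(Cl)c4)CC3)ncnc12`, has not yet been measured. Its change from compound 2 is 3,4-dichlorophenyl in place of 4-methylphenyl on a sulfonyl sulfur. Among the measured compounds shown here, nothing among the measured compounds shows how this exchange of one ring for another on the sulfonyl sulfur plays out, so the expectation rests on the value of compound 2 alone. The step from compound 2 to compound 3 is expected to be small, a 1.4-fold lower number from compound 2 to compound 3 (0.15 log units; within the scatter), and could well fall within the scatter, in either direction. Compound 3 is therefore expected to give about 120 nM in this assay, with a plausible range from 40 nM to 400 nM.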

Compound 3, half-maximal inhibitory concentration: 17 nM
Compound 3: middle estimate off by 7.1-fold (0.85 log units), on the high side; measured number outside the range, below it.
By their numbers in this assay, from the lowest: compound 3; then compound 2; then compound 1.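

The group on the sulfonyl sulfur turns out to be a sensitive place in this series: with the rest of the molecule unchanged, putting 3,4-dichlorophenyl where 4-methylphenyl stood gives a 10-fold lower number from compound 2 to compound 3 (1.00 log units; beyond the scatter) in this assay and so a clearly stronger inhibitor. On paper the exchange is small, since each group is one six-membered carbon ring with no hydrogen-bond donors or acceptors and no net charge, and the incoming group has only one more heavy atom, so a slight edit at this place can move the number a long way. Nothing measured here explains the size of this step.

This single step replaces the methyl group and adds two chlorine atoms at once, so it leaves open whether one chlorine alone, as in 4-chlorophenyl, would do the same, and whether a pyridine ring or a plain alkyl chain on the sulfonyl sulfur would keep the gain. Among these compounds, compound 1 differs from the other two compounds in more than one place, so no step to it can be read.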